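The compounds below may be only part of what the source reports. "The series", "measured", "known", "first", "only" and "open" are said of these compounds alone.

Working notes on the series. In a functional assay on SK-MEL-28 cells (Homo sapiens) for inhibition, read by MTT assay, with a stated time of 48 h (on this read-out lower numbers stand for stronger inhibition and higher numbers for weaker inhibition), compound 1 (`N#Cc1ccc(-c2nc3ccccn3c2Sc2ccccc2)cc1`) gives 67500 nM and compound 2 (`Clc1ccc(-c2nc3ccccn3c2Sc2ccccc2)cc1`) gives 73100 nM. Going by the values given here, compound 2 therefore stands level with compound 1, the only other measured compound, and a 1.1-fold higher number from compound 1 to compound 2 (0.03 log units; within the scatter) does not separate the two.

Compound 3 (`c1ccc(Sc2c(-c3ccsc3)nc3ccccn23)cc1`) has thiophen-3-yl in place of 4-chlorophenyl on an aromatic carbon. Among the compounds with values here, the only measured step that bears on this is a 1.1-fold higher number from compound 1 to compound 2 (0.03 log units; within the scatter). Within the data shown here, that step exchanges a group on the ring that leaves in compound 3, and no measured step replaces the ring itself, so the evidence is thin. In this assay, no step beyond the scatter is expected, and the data favour no direction. The expected change is a 1.1-fold lower number from compound 2 to compound 3 (0.05 log units; within the scatter). For compound 3, the estimated value is 65000 nM, with an expected range of 28000 nM to 150000 nM.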

Compound 3, half-maximal inhibitory concentration: 69300 nM
Beside the measured number, compound 3's estimate is 1.1-fold (0.03 log units) below it; the range from low to high includes it.
By their numbers in this assay, from the lowest: compounds 1, 3 and 2 (each within the scatter of the next).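

In this assay, exchanging the whole ring at this position, rather than only a group on it, gives a 1.1-fold lower number from compound 2 to compound 3 (0.02 log units; within the scatter) and, set against the 4-cyanophenyl compound, a 1.0-fold higher number from compound 1 to compound 3 (0.01 log units; within the scatter). The earlier compounds shown here changed only the group carried on a six-membered aromatic ring of carbon only, whereas thiophen-3-yl shows that a five-membered aromatic ring with 1 hetero atom, with fewer heavy atoms than 4-chlorophenyl, also leaves the number within the scatter of both earlier compounds. Nothing available on these compounds accounts for this lack of separation.

From the compounds shown here alone, it remains open whether the read-out stays level when this position carries something other than an aromatic ring, such as an amine, a carboxylic acid or a longer alkyl chain. The compounds shown also leave open how the number responds to a change in the phenylsulfanyl group, which is the same in all three.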